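Cyclohexyl for 4-propylphenyl on two related cores

The source may hold more compounds than are shown below. What is called first, only, known or untested is meant among the compounds shown, and "the series" means these compounds.

Compound 1 `CCCc1ccc(NC2=CC(=O)c3nc4n(c3C2=O)[C@H]2OC[C@@H](O)[C@H]2OC4)cc1` was tested in a functional assay on ECa-109 cells for inhibition, with ECa-109 cell line (Homo sapiens) as the target, read by sulforhodamine B assay; a higher number here means a weaker inhibitor, a lower number a stronger inhibitor. In this assay compound 1 gives only > 4000 nM, which is a limit of the assay and not a number. Compound 2 `O=C1C=C(NC2CCCCC2)C(=O)c2c1nc1n2[C@H]2OC[C@@H](O)[C@H]2OC1` carries the change (cyclohexyl in place of 4-propylphenyl on an amine nitrogen). In this assay compound 2 likewise gives only the limit > 16000 nM. The step that the two limits leave unreadable from compound 1 to compound 2 cannot be read, since the limit of > 16000 nM in this assay, at which 1 of the 3 values shown sits, and the limit of > 4000 nM in this assay, at which 2 of the 3 values shown sit, are both limits. Compound 3 `CCCc1ccc(NC2=CC(=O)c3c(nc4n3[C@H]3OC[C@@H](O)[C@H]3OC4)C2=O)cc1` has the same atoms as compound 1 joined differently; the difference between the two cores is not broken down here. In this assay compound 3 gives the limit > 4000 nM. Compound 4 `O=C1C(NC2CCCCC2)=CC(=O)c2c1nc1n2[C@H]2OC[C@@H](O)[C@H]2OC1` carries the same change, (cyclohexyl in place of 4-propylphenyl on an amine nitrogen). Compound 4 is expected to remain weak in this assay, with an estimated 20000 nM and an expected step that the limit leaves unreadable from compound 3 to compound 4. That expectation rests on compound 3, which gives only the limit > 4000 nM. It rests also on compound 2, which gives only the limit > 16000 nM.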

Compound 4, half-maximal inhibitory concentration: > 16000 nM
Compound 4: only a limit was reported; the forecaster's own chance of this, stated with the estimate: 85%; the middle value lies beyond the limit too.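

Within the data shown here, compound 3 and compound 4 both give only limits in this assay, so no step between them can be read. The compounds shown leave open how cyclohexyl and 4-propylphenyl compare on any of the related cores.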